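The source may hold more compounds than are shown below. What is called first, only, known or untested is meant among the compounds shown, and "the series" means these compounds.

Measured compounds:
compound 1 `CNC(=O)c1cc(C(=O)Nc2cnn(C)c2)cc2c1OC[C@H]2c1ccccc1` — 3.5
compound 2 `CNC(=O)c1cc(C(=O)N[C@H]2[C@@H]3COC[C@@H]32)cc2c1OC[C@H]2c1cccc2[nH]ccc12` — 3.1
compound 3 `CNC(=O)c1cc(C(=O)N[C@H]2C[C@@H]2C)cc2c1OC[C@@]2(C)c1ccccc1` — 4.7

In a physicochemical assay for lipophilicity, at pH 7.4 (a lower number here means a more polar compound, a higher number a more lipophilic compound), compound 1 gives 3.5, the second highest of the three numbers. Its nearest neighbour is compound 2, which in this assay gives 3.1, a value lower than that of compound 1 by more than the scatter. The furthest is compound 3, which in this assay gives 4.7, the highest of the set and above compound 1 by a margin well beyond the scatter. No pair of these compounds differs in one place only, so the spread between them cannot be tied to a single change.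

Compound 4 `CNC(=O)c1cc(C(N)=O)cc2c1OC[C@H]2c1ccccc1` has not yet been measured. It differs from compound 1 at one place: hydrogen in place of 1-methyl-1H-pyrazol-4-yl on an amide-type nitrogen. The 1-methyl-1H-pyrazol-4-yl group that leaves carries six heavy atoms and two hydrogen-bond acceptors, and nothing but a hydrogen atom takes its place on the amide-type nitrogen.

For the measured compounds named here, with no measured step of this kind to lean on, the step from compound 1 to compound 4 is expected to be clearly downward and beyond the scatter, a number 1.00 log units lower from compound 1 to compound 4 (beyond the scatter). Compound 4 is estimated to come in at 2.5, within a range from 1.9 to 3.1.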

Compound 4, distribution coefficient: 2.7
Compound 4: middle estimate off by 0.20 log units, on the low side; measured number inside the range.
By their numbers in this assay, from the lowest: compound 4; then compound 2; then compound 1; then compound 3.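

In this assay, for the compounds shown here, the change from 1-methyl-1H-pyrazol-4-yl to hydrogen on the amide-type nitrogen gives the first reading of a single change in this set, with a number 0.80 log units lower from compound 1 to compound 4 (beyond the scatter). Going by these compounds alone, this shows that the group at this position can move the number by more than the usual scatter, at least on the core of compound 1, which the earlier compounds could not show because none of them differed in one place only. Nothing measured here accounts for the size of the step, and this one pair cannot show how much of it belongs to the ring and how much to its methyl group.

As far as these compounds go, it remains open whether a group such as ethyl, phenyl or a chain ending in an amine on the same nitrogen would give a number close to that of compound 1, close to that of compound 4, or outside both. Within the data shown here, it also remains open whether the same change would give a step of similar size on a core bearing a different group, such as the one in compound 3.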